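The compounds below may be only part of what the source reports. "The series", "measured", "known", "first", "only" and "open" are said of these compounds alone.

Of the compounds shown here, three of the shared core have been measured in a physicochemical assay for solubility, read by HPLC, using the shake flask method, with a stated time of 2 h, at pH 2; a lower number here means a less soluble compound, a higher number a more soluble compound. Compound 1 `CS(=O)(=O)c1ccc(-c2cnc(N)c(-c3ccc(N)nc3)n2)cc1` gives 206000 nM and compound 3 `CNC(=O)c1ccc(-c2nc(-c3ccc(C(N)=O)cc3)cnc2N)cc1` gives 186000 nM. Compound 2 `Nc1ncc(-c2ccc(C(=O)N3CCC(O)CC3)cc2)nc1-c1ccc(C(F)(F)F)cc1` gives 119000 nM, the lowest of the three numbers, though its gaps to compound 3 and to compound 1 both fall within the scatter, and no order among the three can be read from them. Compound 4 `Nc1ncc(-c2ccc(C(=O)N3CCC(O)C3)cc2)nc1-c1ccc(C(F)(F)F)cc1` has not yet been measured in this assay. It differs from compound 2 in one place: 3-hydroxypyrrolidin-1-yl in place of 4-hydroxypiperidin-1-yl on a carbonyl carbon. Going by the values given here, no measured pair in the set shows this kind of change, and nothing in the numbers points to a direction. The step from compound 2 to compound 4 is expected to stay within the scatter, a 1.0-fold higher number from compound 2 to compound 4 (0.00 log units; within the scatter). Compound 4 is thus estimated at 120000 nM, in the range 60000 nM to 240000 nM.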

Compound 4, solubility: 129000 nM
Compound 4: the middle estimate sits 1.1-fold (0.03 log units) below what was measured, within the range that was stated.
By their numbers in this assay, from the lowest: compounds 2, 4, 3 and 1 (each within the scatter of the next).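

In this assay, going by these compounds alone, the one-place change from 4-hydroxypiperidin-1-yl to 3-hydroxypyrrolidin-1-yl on a carbonyl carbon gives the first direct reading at this position (a 1.1-fold higher number from compound 2 to compound 4 (0.04 log units; within the scatter)). This ring change, which keeps the hydroxyl-bearing ring on the carbonyl, therefore gives no shift that can be told from the scatter. No supporting data bear on why this step is so small.

Going by these compounds, whether a basic amine such as piperazin-1-yl or a carboxylic acid on this carbonyl would also stay within the scatter remains open. So does the reading for a ring without the hydroxyl, such as pyrrolidin-1-yl.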